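Methoxy in place of bromo on the oxadiazoline series

The compounds below may be only part of what the source reports. "The series", "measured", "known", "first", "only" and "open" are said of these compounds alone.

Of the compounds shown here, two sharing one core have been measured in an assay on BTI cells for inhibition of Amine oxidase [flavin-containing] B (Homo sapiens), read by fluorescence and Amplex Red, with a stated time of 15 min; on this read-out lower numbers stand for stronger inhibition and higher numbers for weaker inhibition. Compound 1 `CC(=O)N1N=C(c2ccc([N+](=O)[O-])cc2)O[C@@H]1c1ccc(Cl)c(Cl)c1` gives 7.61 nM. Compound 2 `CC(=O)N1N=C(c2ccc(Br)cc2)OC1c1ccc(Cl)c(Cl)c1` gives 67.7 nM, which is the highest of the two numbers; the nearest value is that of compound 1, and the gap between them lies beyond the scatter. Among the compounds with values here, no pair differing in one place has been measured, so no single step is documented yet.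

Compound 3 `COc1ccc(C2=NN(C(C)=O)C(c3ccc(Cl)c(Cl)c3)O2)cc1` has not been measured in this assay. It differs from compound 2 in one place: methoxy in place of bromo on an aromatic carbon, a change that amounts to methoxy in place of bromo on an aromatic carbon, para to a large group. Nothing in the measured pair shows how this exchange acts on the read-out, so the expectation rests only on the position of compound 2 and on the change itself.

Compound 3 is expected to land near compound 2, with a step from compound 2 to compound 3 of a 1.3-fold higher number from compound 2 to compound 3 (0.12 log units; within the scatter), which is not expected to exceed the scatter clearly in either direction. For compound 3 the estimate in this assay is 90 nM, with a range from 25 nM to 350 nM.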

Compound 3, half-maximal inhibitory concentration: 218 nM
Compound 3: the middle estimate sits 2.4-fold (0.38 log units) below what was measured, within the range that was stated.
By their numbers in this assay, from the lowest: compound 1; then compound 2; then compound 3.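

Going from 4-bromophenyl to 4-methoxyphenyl gives a 3.2-fold higher number from compound 2 to compound 3 (0.51 log units; beyond the scatter) in this assay, the first single-place step documented for this series. Though modest, the step lies beyond the scatter, so this aromatic carbon, para to a large group, is not indifferent to what it carries: here, exchanging one bromine atom for the carbon and oxygen of methoxy, which adds one hydrogen-bond acceptor, goes with weaker inhibition. The compounds offer no measurement that explains this step, so the data record the change in potency but not what lies behind it.

As far as these compounds go, one step at one position establishes no trend, and it remains open how this carbon would respond to an amine, a carboxylic acid, or a longer chain such as ethoxy or propoxy in place of methoxy. From the compounds shown here alone, it is also open whether the exchange of bromo for methoxy would give a step of similar size with a different group on the shared core, or whether this result is specific to compound 2 and compound 3.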